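From tert-butyl to nitro: a single aromatic swap

The compounds below may be only part of what the source reports. "The series", "measured", "known", "first", "only" and "open" are said of these compounds alone.

Measured in a functional assay on QGY7701 cells (Homo sapiens) for cytotoxicity, read by MTT assay, with a stated time of 48 h; a lower number here means a stronger inhibitor, a higher number a weaker inhibitor:
Compound 1 `O=c1ccoc2cc(OCc3cn(Cc4ccc(Cl)cc4)nn3)ccc12` gives 41700 nM.
Compound 2 `O=c1ccoc2cc(OCc3cn(Cc4ccccc4Cl)nn3)ccc12` gives 19700 nM.
Compound 3 `CC(C)(C)c1ccc(Cn2cc(COc3ccc4c(=O)ccoc4c3)nn2)cc1` gives only a limit, > 100000 nM.

Compound 3 stands at the weak end of the three: it sits at the limit of > 100000 nM in this assay, at which 1 of the 3 values shown sits, and the step of an at least 2.3-fold higher number from compound 1 to compound 3 (0.37 log units; beyond the scatter) places it beyond compound 1. Compound 4 `O=c1ccoc2cc(OCc3cn(Cc4ccc([N+](=O)[O-])cc4)nn3)ccc12` differs from compound 3 by nitro in place of tert-butyl on an aromatic carbon. For the measured compounds named here, no measured step exchanges these two groups directly. The step of an at least 2.3-fold higher number from compound 1 to compound 3 (0.37 log units; beyond the scatter) shows that tert-butyl gave a higher number than chloro, and a 2.1-fold lower number from compound 1 to compound 2 (0.33 log units; beyond the scatter) shows that moving a chloro shifted the number modestly. Removing the tert-butyl is therefore expected to bring the number back down, with an expected step of an at least 2.5-fold lower number from compound 3 to compound 4 (0.39 log units; beyond the scatter). Compound 4 is estimated at 40000 nM, within 15000 nM to 100000 nM.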

Compound 4, half-maximal inhibitory concentration: > 100000 nM
Compound 4: only a limit was reported; the forecaster's own chance of this, stated with the estimate: 35%; middle value at least 2.5-fold (0.39 log units) from the limit.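

In this assay, nitro in place of chloro gave an at least 2.3-fold higher number from compound 1 to compound 4 (0.37 log units; beyond the scatter), and 4-nitrophenyl in place of 2-chlorophenyl gave an at least 5.0-fold higher number from compound 2 to compound 4 (0.70 log units; beyond the scatter). The higher number on this aromatic carbon is thus not confined to tert-butyl, as a second and quite different group gives it too. Compound 3 and compound 4 both stand at a limit rather than a number, so the step between them cannot be read: the limit of > 100000 nM in this assay, at which 2 of the 4 values shown sit.

Going by these compounds, whether an amine or a methoxy group on this carbon would keep the number near that of compound 1 remains open. On these data alone, how far compound 3 and compound 4 lie beyond the limit also stays unknown.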